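This account rests on a few compounds, and the source may have more. Where it says the series, first, only, none or still open, it means among the compounds named here.

Among the measured compounds shown here, compound 2 `CCOc1ccc(C2CC2C(=O)NNC(=O)c2ccncc2)cc1` is one of two compounds measured in a functional assay on PC-3 cells (Homo sapiens) for inhibition, read by MTT assay, with a stated time of 72 h; on this read-out lower numbers stand for stronger inhibition and higher numbers for weaker inhibition. Compound 1 `O=C(NNC(=O)C1CC1c1ccc(OCC(F)(F)F)cc1)c1ccncc1` gives 44000 nM there. Compound 2 reaches only a limit, reported as > 100000 nM, so a number is not available for it. Between the two there is one change, methyl in place of trifluoromethyl on a saturated chain carbon bound to an oxygen on an aromatic ring, and the step is an at least 2.2-fold higher number from compound 1 to compound 2 (0.35 log units; beyond the scatter); its size can be stated only as a lower bound because one of the two values is a limit (the limit of > 100000 nM in this assay, at which 1 of the 2 values shown sits).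

Compound 3 `O=C(NNC(=O)C1CC1c1ccc(OC(F)(F)F)cc1)c1ccncc1` differs from compound 2 by trifluoromethyl in place of ethyl on an oxygen on an aromatic ring. For the measured compounds named here, the measured step that bears on it is the one from compound 1 to compound 2, where fluorine entering the chain on that oxygen went with the stronger number; fluorine enters again here, though now directly on the oxygen. Compound 3 is therefore expected to move back toward a measurable number, with a step from the limit of compound 2 estimated as an at least 1.6-fold lower number from compound 2 to compound 3 (0.22 log units; that floor lies within the scatter). The estimate for compound 3 in this assay is 60000 nM, in a range from 20000 nM to 150000 nM.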

Compound 3, half-maximal inhibitory concentration: > 100000 nM
Compound 3: only a limit was reported; the forecaster's own chance of this, stated with the estimate: 35%; middle value at least 1.6-fold (0.22 log units) away from the limit.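

In this assay compound 3 also gives only a limit, > 100000 nM, and not a number. Trifluoromethyl in place of 2,2,2-trifluoroethyl on the oxygen gives an at least 2.2-fold higher number from compound 1 to compound 3 (0.35 log units; beyond the scatter), so fluorine on this oxygen does not by itself go with a measurable number: among these three compounds only the 2,2,2-trifluoroethyl group gives one, and compound 3, which carries fluorine there, goes against any simple link between fluorine and a measurable number. The step between compound 2 and compound 3 cannot be read because both stand at the same limit: the limit of > 100000 nM in this assay, at which 2 of the 3 values shown sit.

With a single number in the set, the compounds shown leave open whether the reading of compound 1 depends on the fluorine atoms, on the length of the chain on the oxygen, or on both together. On these data alone, how a longer chain such as 3,3,3-trifluoropropyl, or a chain ending in an amine or a carboxylic acid, would read at this oxygen also remains open.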